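The source may hold more compounds than are shown below. What is called first, only, known or untested is meant among the compounds shown, and "the series" means these compounds.

Compound 2 `CC(=O)N[C@H]1[C@@H](OC[C@@H](O)[C@@H](O)[C@H](O)[C@@H](O)CNc2cccc(NC(=O)CCCCC3CCSS3)c2)O[C@H](CO)[C@H](O)[C@@H]1O[C@@H]1O[C@H](C(=O)O)[C@@H](O)[C@H](O)[C@H]1OS(=O)(=O)O` — 62 nM
Compound 3 `CC(=O)N[C@H]1[C@@H](OC[C@@H](O)[C@@H](O)[C@H](O)[C@@H](O)CNc2cccc(NC(=O)CCCCC3CCSS3)c2)O[C@H](CO)[C@H](OS(=O)(=O)O)[C@@H]1O[C@@H]1O[C@H](C(=O)O)[C@@H](O)[C@H](O)[C@H]1OS(=O)(=O)O` — 41 nM
Compound 1 `CC(=O)N[C@H]1[C@@H](OC[C@@H](O)[C@@H](O)[C@H](O)[C@@H](O)CNc2cccc(NC(=O)CCCCC3CCSS3)c2)O[C@H](COS(=O)(=O)O)[C@H](O)[C@@H]1O[C@@H]1O[C@H](C(=O)O)[C@@H](O)[C@H](O)[C@H]1O` — 36 nM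

In an assay on isolated protein for binding affinity to fibroblast growth factor 2 (Homo sapiens), read by surface plasmon resonance (a lower number here means tighter binding, a higher number weaker binding), compound 2 gives the highest of the three numbers shown, yet neither neighbour separates from it: compound 3, the nearest, differs by a 1.5-fold lower number from compound 2 to compound 3 (0.18 log units; within the scatter), and compound 1, the furthest, sits close enough that the two values show no difference beyond the usual scatter. Compound 4 `CC(=O)N[C@H]1[C@@H](OC[C@@H](O)[C@@H](O)[C@H](O)[C@@H](O)CNc2cccc(NC(=O)CCCCC3CCSS3)c2)O[C@H](COS(=O)(=O)O)[C@H](O)[C@@H]1O[C@@H]1O[C@H](C(=O)O)[C@@H](O)[C@H](O)[C@H]1OS(=O)(=O)O` has not yet been measured. Its change from compound 2 is sulfo in place of hydrogen on an oxygen on a saturated carbon; the same kind of change, read one bond further out, turns a hydroxymethyl into a (sulfooxy)methyl. Among the compounds with values here, the one measured step that bears on it is the step from compound 2 to compound 3, where a sulfo group likewise replaced a hydrogen on an oxygen on a saturated carbon and the number moved by a 1.5-fold lower number from compound 2 to compound 3 (0.18 log units; within the scatter), within the scatter. Compound 1, which carries the (sulfooxy)methyl group but not the second sulfo group, shows a value near that of compound 2. On this basis compound 4 is expected to move by a 1.4-fold lower number from compound 2 to compound 4 (0.14 log units; within the scatter) in this assay, a shift that would not stand out from the scatter. The estimate for compound 4 is 45 nM, with a range from 22 nM to 90 nM.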

Compound 4, dissociation constant: 23 nM
Compound 4: the middle estimate sits 2.0-fold (0.29 log units) above what was measured; the measured number falls inside the stated range.
By their numbers in this assay, from the lowest: compounds 4, 1, 3 and 2 (each within the scatter of the next, the first and the last beyond it).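

In this assay, within the data shown here, putting a sulfo group on the hydroxymethyl of compound 2 gives a 2.7-fold lower number from compound 2 to compound 4 (0.43 log units; beyond the scatter), the first single change to clear the scatter, though only modestly. The (sulfooxy)methyl group therefore shows a measurable effect in the presence of the second sulfo group carried by compound 2, which the values of compounds 1, 2 and 3 could not show, as none of their differences stood out. Adding a sulfo group to compound 1 is a different matter, with a 1.6-fold lower number from compound 1 to compound 4 (0.19 log units; within the scatter), and this small step matches the one already seen on another core: the same change on two cores in this assay, a 1.5-fold lower number (0.18 log units; within the scatter) from compound 2 to compound 3 and a 1.6-fold lower number (0.19 log units; within the scatter) from compound 1 to compound 4, 1.0-fold (0.01 log units) apart, within the scatter of two such steps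

Going by these compounds, what a phosphate group or a carboxylic acid in place of the sulfooxy group would do at this position remains open. So does whether the step to a (sulfooxy)methyl holds on a core that carries no other sulfo group, or whether a longer chain between the saturated carbon and the sulfooxy group would keep it.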